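Replacing propanoyl by a thiourea-type group in compound 1

The source may hold more compounds than are shown below. What is called first, only, known or untested is meant among the compounds shown, and "the series" means these compounds.

Compound 1 `CCC(=O)NCCC(=O)c1cc(OC)ccc1N`: 0.24%
Compound 2 `CCCCC(=O)NCCC(=O)c1cc(OC)ccc1N`: 14.1%
Compound 3 `CC(=O)NCCC(=O)c1cc(Cl)ccc1N`: 19.7%

In an assay for inhibition of Nitric oxide synthase, inducible (Homo sapiens), read by scintillation counting, with a stated time of 30 min, tested at 1 mM (a higher number here means more inhibition at the concentration tested (going by the name of the read-out), a lower number less inhibition), compound 1 stands lowest of the three measured compounds; compound 2 lies nearest, and compound 3 furthest above it. Going by the values given here, the only step between measured compounds that differ in one place is a number 13.9 percentage points higher from compound 1 to compound 2 (beyond the scatter), a lengthening of the chain rather than an exchange of the whole group. Compound 4 `CNC(=S)NCCC(=O)c1cc(OC)ccc1N` differs from compound 1 in this way: a group of 4 heavy atoms (2 carbon, 1 nitrogen, 1 sulfur; no ring) in place of a group of 4 heavy atoms (3 carbon, 1 oxygen; no ring), on an amine nitrogen. Among the compounds with values here, no measured step exchanges the group on the amine nitrogen, so that step gives only a weak guide. Compound 4 is expected to show a small rise, a number 9.8 percentage points higher from compound 1 to compound 4 (within the scatter), to an estimated 10%, with a range from 0% to 35%.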

Compound 4, a percentage reported as inhibition, at one concentration (the size of the read-out at that concentration, not a potency): 78.2%
For compound 4 the middle estimate is 68.2 percentage points below the measured one; the whole stated range lies below it.
By their numbers in this assay, from the lowest: compound 1; then compounds 2 and 3 (each within the scatter of the next); then compound 4.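

In this assay, the group on the amine nitrogen turns out to matter far more than the chain lengthening alone suggested. Exchanging propanoyl for the sulfur-containing group of 4 heavy atoms, with heavy-atom count unchanged, gives a number 78 percentage points higher from compound 1 to compound 4 (beyond the scatter) and the same entering group gives a number 64.1 percentage points higher from compound 2 to compound 4 (beyond the scatter) against the longer acyl group. No evidence here explains this rise.

The compounds shown leave open whether the sulfur or the added nitrogen carries the gain, which the matching urea with oxygen in place of sulfur would separate. Also open, on these data alone, is how an ethyl or phenyl group on the thiourea nitrogen would read.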